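Lengthening the Alkyl Chain in a Kallikrein-5 Inhibitor Series

The compounds below may be only part of what the source reports. "The series", "measured", "known", "first", "only" and "open" are said of these compounds alone.

Measured so far:
- Compound 1 `CCCCCCCCCCC/C(O)=C1/C(=O)[C@H](Cc2ccccc2)N(C(=O)OC(C)(C)C)C1=O`: in an assay on isolated protein for inhibition of kallikrein-5 (Homo sapiens) (a higher number here means a weaker inhibitor, a lower number a stronger inhibitor), compound 1 gives 3600 nM.
- Compound 2 `CCCCCCCCCCCCC/C(O)=C1/C(=O)[C@H](Cc2ccccc2)N(C(=O)OC(C)(C)C)C1=O`: in this assay compound 2 gives 4900 nM.

Among the compounds with values here, compound 2 has the highest of the two numbers so far, but its only neighbour is compound 1, and the step of a 1.4-fold higher number from compound 1 to compound 2 (0.13 log units; within the scatter) lies within the scatter, so the two compounds cannot be told apart on these data.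

Compound 3 `CCCCCCCCCCCCCCC/C(O)=C1/C(=O)[C@H](Cc2ccccc2)N(C(=O)OC(C)(C)C)C1=O` carries the same change once more: ethyl in place of hydrogen on a saturated chain carbon, ten or more bonds along the chain from a double-bonded chain carbon. Within the data shown here, the one measured step that bears on it, a 1.4-fold higher number from compound 1 to compound 2 (0.13 log units; within the scatter), came from the same kind of chain extension and did not move the number beyond the scatter. The step of a 1.2-fold higher number from compound 2 to compound 3 (0.09 log units; within the scatter) is therefore expected to be small, with no clear direction beyond the scatter. Compound 3 is estimated at 6000 nM, within a range from 2500 nM to 15000 nM.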

Compound 3, half-maximal inhibitory concentration: 12000 nM
For compound 3 the middle estimate is 2.0-fold (0.30 log units) below the measured one, and the stated range covers the measured number.
By their numbers in this assay, from the lowest: compounds 1 and 2 (each within the scatter of the next); then compound 3.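

In this assay, the same ethyl in place of hydrogen on the saturated chain carbon now gives a 2.4-fold higher number from compound 2 to compound 3 (0.39 log units; beyond the scatter), so extending the chain at this position can weaken inhibition by more than the scatter, which the earlier pair could not show. Over the whole extension, butyl in place of hydrogen gives a 3.3-fold higher number from compound 1 to compound 3 (0.52 log units; beyond the scatter), a modest loss that sets compound 3 apart from compounds 1 and 2, which remain within the scatter of each other. The change in this series therefore does not appear evenly with each added ethyl.

The compounds shown leave open whether a still longer chain would weaken inhibition further, and how an amine or a carboxylic acid at the end of the chain would compare. Nothing available explains why this chain extension shifts the number.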